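Swapping Hydroxy for Amino on the Aryl Ring of Compound 2

A few compounds are considered here, and "the series" means these few. Any claim that something is new, unique, unknown or untested is made for them only; others in the source may bear on it.

Of the compounds shown here, two sharing one core have been tested in a functional assay on HCT-116 cells (Homo sapiens) for cytotoxicity, read by MTT assay, with a stated time of 48 h; a lower number here means a stronger inhibitor, a higher number a weaker inhibitor. Compound 1 `O=C(/C=C/c1ccc2c(c1)B(O)OC2)c1cccnc1` carries a pyridin-3-yl on the carbonyl carbon, and in this assay compound 1 gives 20500 nM. Compound 2 `O=C(/C=C/c1ccc2c(c1)B(O)OC2)c1ccc(O)cc1` carries a 4-hydroxyphenyl there instead, and in this assay compound 2 gives 24100 nM. The move a 1.2-fold higher number from compound 1 to compound 2 (0.07 log units; within the scatter) is within the scatter, so the two numbers cannot be told apart, and compound 2 stands beside compound 1 with no separable difference. Compound 3 `Nc1ccc(C(=O)/C=C/c2ccc3c(c2)B(O)OC3)cc1` differs from compound 2 by amino in place of hydroxy on an aromatic carbon. Within the data shown here, no measured step concerns this exact swap; the only step available, from compound 1 to compound 2, exchanged the whole aryl group on the carbonyl carbon and still stayed within the scatter, which gives no reason to expect a large move now. The expected step of a 1.0-fold lower number from compound 2 to compound 3 (0.00 log units; within the scatter) is therefore none beyond the scatter. Compound 3 is estimated at 24000 nM, with a likely range from 10000 nM to 55000 nM.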

Compound 3, half-maximal inhibitory concentration: 26100 nM
The estimate for compound 3 lay 1.1-fold (0.04 log units) below the measured number; the range from low to high includes it.
By their numbers in this assay, from the lowest: compounds 1, 2 and 3 (each within the scatter of the next).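

In this assay, the exchange of hydroxy for amino on the aromatic carbon para to a large group gives a 1.1-fold higher number from compound 2 to compound 3 (0.03 log units; within the scatter), so this single-atom change at this position leaves no separable difference. The earlier step replaced a whole aryl group, whereas this one alters only the group on the ring, and the remaining pair gives a 1.3-fold higher number from compound 1 to compound 3 (0.10 log units; within the scatter), so pyridin-3-yl, 4-hydroxyphenyl and 4-aminophenyl on the carbonyl carbon cannot be told apart by this measurement. No supporting measurement is available to explain why these numbers cannot be separated.

On these data alone, whether a carboxylic acid, a methoxy group or a longer chain at the same ring position would give a step beyond the scatter remains open. The three compounds also leave open whether the amino group would behave the same way elsewhere on the ring.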